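The source may report more compounds than this note shows. Statements on the series, on what has been measured and on what is new or still open speak of the compounds shown alone.

Measured so far in a functional assay on PC-3 cells (Homo sapiens) for antiproliferative activity, read by MTT assay, with a stated time of 24 h; on this read-out higher numbers stand for weaker inhibition and lower numbers for stronger inhibition:
- compound 1 `CCn1c(C(=O)NC(C)(C)CO)ccc1C(CC)(CC)c1ccc(OCS(=O)(=O)c2ccccc2)c(C)c1`: 9850 nM
- compound 2 `CCn1c(C(=O)N[C@@H](C)C(=O)O)ccc1C(CC)(CC)c1ccc(OCS(=O)(=O)c2ccccc2)c(C)c1`: 16800 nM

Within the data shown here, compound 2 gives 16800 nM, which lies within the scatter of the only other number. Compound 3 `CCn1c(C(=O)NCCC(=O)O)ccc1C(CC)(CC)c1ccc(OCS(=O)(=O)c2ccccc2)c(C)c1` differs from compound 2 in one place: 2-carboxyethyl in place of 1-carboxyethyl on an amide-type nitrogen. In words, 2-carboxyethyl stands in place of 1-carboxyethyl on an amide-type nitrogen.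

Among the measured compounds shown here, the only measured step that bears on this change is a 1.7-fold higher number from compound 1 to compound 2 (0.23 log units; within the scatter). It concerns the same nitrogen and stays within the scatter. For the measured compounds named here, no measured pair compares 2-carboxyethyl with 1-carboxyethyl directly, so no step beyond the scatter is expected in this assay, and no direction is favoured. The expected step is a 1.1-fold lower number from compound 2 to compound 3 (0.05 log units; within the scatter). The estimate for compound 3 is 15000 nM, with an expected range of 7000 nM to 32000 nM.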

Compound 3, half-maximal inhibitory concentration: 14400 nM
Beside the measured number, compound 3's estimate is 1.0-fold (0.02 log units) above it; measured number inside the range.
By their numbers in this assay, from the lowest: compounds 1, 3 and 2 (each within the scatter of the next).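

In this assay, 2-carboxyethyl in place of 1-carboxyethyl on the amide-type nitrogen gives a 1.2-fold lower number from compound 2 to compound 3 (0.07 log units; within the scatter), so this exchange of connectivity, which also removes the defined stereocentre, stays within the scatter. Against the 1-(hydroxymethyl)-1-methylethyl group, 2-carboxyethyl gives a 1.5-fold higher number from compound 1 to compound 3 (0.16 log units; within the scatter), so all three groups on this nitrogen now lie within the scatter of one another, and the series shows no preference among them at this position. No supporting data bear on this result.

Going by these compounds, whether a step beyond the scatter can be reached at this nitrogen remains open, for example with a basic amine, a methyl ester of the acid or a longer chain such as 3-carboxypropyl. The mirror-image form of the 1-carboxyethyl group also remains to be compared with compound 2.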